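Isopropyl to 1-hydroxyethyl: an expected small step

The source may hold more compounds than are shown below. What is called first, only, known or untested is meant among the compounds shown, and "the series" means these compounds.

Measured in a functional assay on WiDr cells (Homo sapiens) for antiproliferative activity, read by sulforhodamine B assay, with a stated time of 48 h (on this read-out lower numbers stand for stronger inhibition of growth and higher numbers for weaker inhibition of growth), so far:
- compound 1 `CCCCCCCCCCCCCCC[C@@H](O)[C@@H](N)[C@@H](C)O` gives 18000 nM
- compound 2 `CCCCCCCCC[C@@H](O)[C@@H](N)[C@@H](C)CC` gives 2300 nM
- compound 3 `CCCCCCCCC[C@@H](O)[C@@H](N)C(C)C` gives 11000 nM

Compound 3 lies within the scatter of compound 1 and clear of compound 2, with a 4.8-fold higher number from compound 2 to compound 3 (0.68 log units; beyond the scatter) in this record.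

The next compound, compound 4 `CCCCCCCCC[C@@H](O)[C@@H](N)[C@@H](C)O`, carries 1-hydroxyethyl in place of isopropyl on a saturated chain carbon bound to an amine nitrogen and a saturated chain carbon, and the count reads 1-hydroxyethyl in place of isopropyl on a saturated chain carbon bound to an amine nitrogen and a saturated chain carbon here.

Within the data shown here, only one measured step bears on this change, the modest 4.8-fold higher number from compound 2 to compound 3 (0.68 log units; beyond the scatter) above. That step is hydrogen in place of methyl and brings in no hydroxyl, so it is a loose guide. Compound 1 also holds a 1-hydroxyethyl group, but its chain is longer, and its 18000 nM sits within the scatter of compound 3. No measurement isolates this swap, so no step beyond the scatter is expected in this assay for now.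

The expected change is a 1.3-fold higher number from compound 3 to compound 4 (0.10 log units; within the scatter) as a rough estimate.

The estimated value for compound 4 is 14000 nM with an expected range from 5000 nM to 40000 nM in this test.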

Compound 4, concentration for 50% growth inhibition: 14000 nM
The estimate for compound 4 equals the measured number at the digits printed; low and high end bracket the measured number.
By their numbers in this assay, from the lowest: compound 2; then compounds 3, 4 and 1 (each within the scatter of the next).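

In this assay, 1-hydroxyethyl in place of isopropyl on a saturated chain carbon bound to an amine nitrogen and a saturated chain carbon gives a 1.3-fold higher number from compound 3 to compound 4 (0.10 log units; within the scatter) here, so these two groups cannot be told apart at this position. Compound 2 stays apart, with hydroxy in place of ethyl on a saturated chain carbon bound to two saturated chain carbons giving a 6.1-fold higher number from compound 2 to compound 4 (0.78 log units; beyond the scatter) in the same test, which leaves it alone among the four compounds in standing clear of the others. Hydrogen in place of hexyl gives a 1.3-fold lower number from compound 1 to compound 4 (0.11 log units; within the scatter), so that longer chain does not separate compound 1 from compound 4.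

Still open, as far as these compounds go, is whether an amine or a carboxylic acid in this place would fall with compound 4 or with compound 2. Nothing on hand explains why compound 2 stands apart.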